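The source may hold more compounds than are shown below. What is called first, only, known or untested is meant among the compounds shown, and "the series" means these compounds.

Measured compounds in a functional assay on blood for antagonist activity at thromboxane A2 receptor (Homo sapiens); on this read-out lower numbers stand for tighter binding and higher numbers for weaker binding:

Compound 1, `NC(=O)Cc1ccccc1-c1ccc(COC2CC[C@H](N3CCCCCC3)[C@H]2OC/C=C\CCC(=O)O)cc1`: 7.94 nM
Compound 2, `O=C(O)CC/C=C\CO[C@H]1[C@H](OCc2ccc(-c3ccccc3CO)cc2)CC[C@@H]1N1CCCCCC1`: 6.31 nM
Compound 3, `O=C(O)CC/C=C\CO[C@H]1[C@@H](OCc2ccc(-c3ccccc3)cc2)CC[C@@H]1N1CCCCCC1`: 5.01 nM

Compound 1 gives the highest of the three numbers, but its distance to compound 2 and to compound 3 lies within the scatter, so the three compounds cannot be ordered against one another in this assay. Among the measured compounds shown here, the set is small and offers no single-change pair, so no measured step is available for guidance; what is known is that the three substituents on the distal aromatic ring of the shared core all land in the same narrow band.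

Compound 4, `O=C(O)CC/C=C\CO[C@H]1C(OCc2ccc(-c3ccc(CO)cc3)cc2)CC[C@@H]1N1CCCCCC1`, has not been measured. It differs from compound 1 by a group of 8 heavy atoms (7 carbon, 1 oxygen; one six-membered aromatic ring of carbon only) in place of a group of 10 heavy atoms (8 carbon, 1 nitrogen, 1 oxygen; one six-membered aromatic ring of carbon only), on an aromatic carbon. Compound 2 already carries a hydroxymethyl on that ring and sits within the scatter of compound 1, as does unsubstituted compound 3, so the change is expected to leave the number where it is, with no step beyond the scatter in either direction. The step from compound 1 to compound 4 is therefore estimated as a 1.3-fold lower number from compound 1 to compound 4 (0.10 log units; within the scatter). For compound 4 in this assay the expected value is 6.3 nM, within an estimated range from 2.5 nM to 16 nM.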

Compound 4, dissociation constant: 3.16 nM
Compound 4: middle estimate off by 2.0-fold (0.30 log units), on the high side, and the stated range covers the measured number.
By their numbers in this assay, from the lowest: compounds 4, 3, 2 and 1 (each within the scatter of the next, the first and the last beyond it).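

In this assay, among the compounds shown here, 4-(hydroxymethyl)phenyl in place of the larger group of compound 1 gives a 2.5-fold lower number from compound 1 to compound 4 (0.40 log units; beyond the scatter), the first step that is read beyond the scatter. For the compounds shown here, the earlier compounds offered no single-change pair, so this is the first direct sign that the number responds to what is carried on this aromatic carbon, para to a large group, although the step is modest and rests on a single pair. No measurement is at hand that bears on the origin of this step.

The entering and leaving groups differ both in the substituent on the outer aromatic ring and in where that substituent sits, so this one step cannot assign the shift to either difference alone. Also open, as far as these compounds go, is whether the same position would tolerate an aminomethyl group, a carboxylic acid or a longer hydroxyalkyl chain in place of the hydroxymethyl, and whether any of these would move the number further in either direction.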